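The source may hold more compounds than are shown below. What is called first, only, known or untested is meant among the compounds shown, and "the series" means these compounds.

Series notes, two compounds measured in a functional assay on MCF7 cells (Homo sapiens) for cytotoxicity, read by MTT assay, with a stated time of 2 days, tested at 0.1 uM; on this read-out lower numbers stand for a stronger effect and higher numbers for a weaker effect at the one concentration tested. Compound 1 `CC(=O)c1cc(-c2ccc(F)cc2)cc2cc(-c3ccc(F)cc3)[nH]c12` gives 99.8% in this assay. Compound 2 `COc1ccc(-c2cc3cc(-c4ccccc4)cc(C(C)=O)c3[nH]2)cc1` gives 87%, the lower of the two numbers; its gap to compound 1 lies beyond the scatter, but the two compounds differ in more than one place, so no single step can be read from that pair. Compound 3 `COc1ccc(-c2cc3cc(-c4ccc(F)cc4)cc(C(C)=O)c3[nH]2)cc1` has not yet been measured; it differs from compound 2 by fluoro in place of hydrogen on an aromatic carbon. Within the data shown here, no pair of measured compounds shows the effect of this change on its own, so the size of the step can only be expected as small. The step expected in this assay is a number 4 percentage points higher from compound 2 to compound 3 (within the scatter), not beyond the scatter. Compound 3 is estimated at 91% in this assay, with a range from 78% to 101%.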

Compound 3, a percentage reported as activity, at one concentration (the size of the read-out at that concentration, not a potency): 97.3%
Compound 3: middle estimate off by 6.3 percentage points, on the low side; low and high end bracket the measured number.
By their numbers in this assay, from the lowest: compound 2; then compounds 3 and 1 (each within the scatter of the next).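

In this assay, among these compounds, phenyl to 4-fluorophenyl gives the first step that can be read in one place, a number 10.3 percentage points higher from compound 2 to compound 3 (beyond the scatter) and so fluoro in place of hydrogen at this position, para to a large group, shifts the read-out modestly towards a weaker effect. The second change in one place, methoxy in place of fluoro on an aromatic carbon, reads a number 2.5 percentage points lower from compound 1 to compound 3 (within the scatter) and so cannot be told apart from the scatter in this assay. No measurement at hand bears on the reason for either step.

Going by these compounds, whether chloro or an amine on the same aromatic carbon would give a step of similar size remains open. A reading at one concentration also gives no potency for compound 1, compound 2 or compound 3.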